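The compounds below may be only part of what the source reports. "The series", "measured", "known", "first", "only" and "open" are said of these compounds alone.

Measured so far:
compound 1, `COc1cc(OC)c2c(=O)cc(-c3ccccc3Cl)oc2c1CN1CCCCC1`: 23700 nM
compound 2, `CCN(CC)Cc1c(OC)cc(OC)c(C(=O)/C=C/c2ccccc2Cl)c1O`: 2700 nM

Both numbers come from a functional assay on MCF7 cells (Homo sapiens) for antiproliferative activity, with a stated time of 72 h; a lower number here means a stronger inhibitor, a higher number a weaker inhibitor. Of the two, compound 2 gives the lower number, and the gap to compound 1 lies beyond the scatter, so compound 2 is the stronger inhibitor of the pair. Among the measured compounds shown here, compound 1 differs from compound 2 in more than one place, so the two values show only that the pair differ, not which change carries the difference.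

Compound 3 is `COC(=O)CN(C)Cc1c(OC)cc(OC)c(C(=O)/C=C/c2ccccc2Cl)c1O`. It keeps the core of compound 2 and differs from it in one place: ((methoxycarbonyl)methyl)(methyl)amino in place of diethylamino on a saturated chain carbon bound to an aromatic carbon. The incoming group is the larger of the two; neither carries a charge.

For the measured compounds named here, no measured step between compounds differing in one place exists, so nothing yet shows how this assay responds to a change at this position. The expected step, a 1.4-fold higher number from compound 2 to compound 3 (0.15 log units; within the scatter), is small, toward a weaker inhibitor, and within or only just beyond the scatter. Compound 3 is expected to give 3800 nM in this assay, with a range from 1200 nM to 12000 nM.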

Compound 3, half-maximal inhibitory concentration: 10600 nM
Compound 3: middle estimate off by 2.8-fold (0.45 log units), on the low side; measured number inside the range.
By their numbers in this assay, from the lowest: compound 2; then compound 3; then compound 1.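

In this assay, among the compounds shown here, ((methoxycarbonyl)methyl)(methyl)amino in place of diethylamino on a saturated chain carbon bound to an aromatic carbon gives a 3.9-fold higher number from compound 2 to compound 3 (0.59 log units; beyond the scatter), the first single-place step, and it shows that this position is not silent: the change moves the series modestly toward a weaker inhibitor. The incoming group differs from diethylamino in several ways at once, with more heavy atoms, more hydrogen-bond acceptors and a double bond outside aromatic rings, while neither group carries a charge, so this single step cannot assign the loss to any one of these features. No supporting measurement bears on the result, and the step stands without an explanation.

The compounds shown leave open whether the step follows from the methoxycarbonyl part or from the loss of the ethyl groups. A dimethylamino group would test the amine substituents without the ester, and a carboxylic acid in place of the methyl ester would test the ester itself.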